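Trifluoromethyl in place of fluoro on the pendant phenyl ring

The compounds below may be only part of what the source reports. "The series", "measured", "known", "first", "only" and "open" are said of these compounds alone.

Two analogues sharing one core have been measured in a functional assay on HCT-116 cells (Homo sapiens) for inhibition, read by sulforhodamine B assay, with a stated time of 72 h; on this read-out higher numbers stand for weaker inhibition and lower numbers for stronger inhibition. Compound 1 `COc1ccc2cc(C(C)c3nnc4n3N=C(c3ccc(OC(F)(F)F)cc3)CS4)ccc2c1` gives 11700 nM there, and compound 2 `COc1ccc2cc(C(C)c3nnc4n3N=C(c3ccc(F)cc3)CS4)ccc2c1` gives 13100 nM. Among the compounds with values here, compound 2 thus holds the higher of the two numbers, with compound 1 as its only neighbour, and the gap between them lies within the scatter, so neither can be called the stronger inhibitor.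

Compound 3 `COc1ccc2cc(C(C)c3nnc4n3N=C(c3ccc(C(F)(F)F)cc3)CS4)ccc2c1` has not yet been measured. It differs from compound 2 by trifluoromethyl in place of fluoro on an aromatic carbon. Within the data shown here, the one measured step that bears on this exchange is a 1.1-fold higher number from compound 1 to compound 2 (0.05 log units; within the scatter), which likewise replaced one fluorine-bearing group by another on the same aromatic carbon and left the read-out where it was. Because that step a 1.1-fold higher number from compound 1 to compound 2 (0.05 log units; within the scatter) stayed within the scatter, the present exchange is expected to shift this assay by a 1.0-fold lower number from compound 2 to compound 3 (0.02 log units; within the scatter), that is, by nothing beyond the scatter in either direction. Compound 3 is therefore estimated at 12500 nM in this assay, with a range from 5000 nM to 30000 nM.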

Compound 3, half-maximal inhibitory concentration: 10800 nM
Compound 3: the middle estimate sits 1.2-fold (0.06 log units) above what was measured; low and high end bracket the measured number.
By their numbers in this assay, from the lowest: compounds 3, 1 and 2 (each within the scatter of the next).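

In this assay, the exchange of 4-fluorophenyl for 4-(trifluoromethyl)phenyl gives a 1.2-fold lower number from compound 2 to compound 3 (0.08 log units; within the scatter), so going from one heavy atom to four at this aromatic carbon, para to a large group, leaves the read-out within the scatter. Within the data shown here, exchanging trifluoromethoxy for trifluoromethyl at the same carbon gives a 1.1-fold lower number from compound 1 to compound 3 (0.03 log units; within the scatter), which completes the set: fluoro, trifluoromethoxy and trifluoromethyl now stand within the scatter of one another in every pairing, whereas the earlier compounds offered only a single pair. No measurement at hand accounts for this lack of separation.

All three groups at this position carry fluorine, so the compounds shown leave open whether a group without it, such as an amine, a carboxylic acid or a longer alkyl chain, would give a step beyond the scatter. They also leave open whether the same insensitivity would hold at another carbon of this ring, or where the methoxy group or the methyl-bearing carbon of the shared core is changed.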